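Sulfonyl Aryl Exchange Under Antiproliferative Limits

The source may report more compounds than this note shows. Statements on the series, on what has been measured and on what is new or still open speak of the compounds shown alone.

Compound 1 `COc1ccc(-c2cc(=O)c3c(OC)cc(OC)cc3n2S(=O)(=O)c2cccc([N+](=O)[O-])c2)cc1`: in an ADME assay on BJ cells (Homo sapiens) for antiproliferative activity, with a stated time of 72 h (a higher number here means that more compound is needed for the effect, a lower number that less compound is needed), compound 1 gives > 39600 nM, a limit of the assay.
Compound 2 `COc1ccc(-c2cc(=O)c3c(OC)cc(OC)cc3n2S(=O)(=O)c2cc(F)c(F)c(F)c2)cc1`: compound 2 gives > 65500 nM, a limit.
Compound 3 `COc1ccc(-c2cc(=O)c3c(OC)cc(OC)cc3n2S(=O)(=O)c2c(F)c(F)c(F)c(F)c2F)cc1`: compound 3 gives > 34400 nM, a limit.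

All three numbers are limits, so compound 3 stands at a limit alongside the other two, and the steps a step that the two limits leave unreadable from compound 1 to compound 2, a step that the two limits leave unreadable from compound 1 to compound 3 and a step that the two limits leave unreadable from compound 2 to compound 3 cannot be read in size or direction. Compound 4 `COc1ccc(-c2cc(=O)c3c(OC)cc(OC)cc3n2S(=O)(=O)c2ccc(C)cc2)cc1` differs from compound 3 by 4-methylphenyl in place of 2,3,4,5,6-pentafluorophenyl on a sulfonyl sulfur. Going by the values given here, no measured step bears readably on this change, since every step involving the sulfonyl aryl group here ends at a limit. Compound 4 is therefore expected to sit at a limit as well, estimated at 40000 nM with a range from 15000 nM to 100000 nM. The step that the limit leaves unreadable from compound 3 to compound 4 is expected to stay within the scatter.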

Compound 4, half-maximal effective concentration: > 44800 nM
Compound 4 was reported as a limit (the forecaster's own chance of this, stated with the estimate: 80%); middle value at least 1.1-fold (0.04 log units) from the limit.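

Compound 4 also stands at a limit, so its steps from compound 1, compound 2 and compound 3 cannot be read. The compounds shown leave open whether exchanging the aryl group on the sulfonyl sulfur changes the result in this assay at all.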